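The compounds below may be only part of what the source reports. "The series", "measured", "known", "first", "only" and "open" are said of these compounds alone.

Measured so far:
- compound 1 `O=C(NCc1cccc(F)c1)c1nc([N+](=O)[O-])c(Sc2c(Cl)cncc2Cl)s1`: 6360 nM
- compound 2 `COc1ccc(Sc2sc(C(C)=O)nc2[N+](=O)[O-])cc1OC`: 24000 nM
- compound 3 `CC(=O)c1nc([N+](=O)[O-])c(NCc2ccc(Cl)c(Cl)c2)s1`: > 50000 nM (a limit, not a number)

The measure here is a functional assay on HCT-116 cells (Homo sapiens) for antiproliferative activity, read by MTT assay, with a stated time of 72 h; a higher number here means a weaker inhibitor, a lower number a stronger inhibitor. Compound 2 gives 24000 nM and compound 1 gives 6360 nM, the lower of the two actual numbers, and the gap between them lies beyond the usual scatter. Compound 3 reads > 50000 nM, which is a limit of the assay.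

Compound 4 `Cc1ccc(CNC(=O)c2nc([N+](=O)[O-])c(Sc3c(Cl)cncc3Cl)s2)cc1` keeps the core of compound 1 but carries 4-methylphenyl in place of 3-fluorophenyl on a saturated chain carbon bound to an amide-type nitrogen. Within the data shown here, no two measured compounds differ in one place only, so no measured step serves as a guide to this swap. With that lack of direct evidence, the expectation in this assay is no step beyond the scatter, in either direction, starting from compound 1 at 6360 nM. The expected step of a 1.0-fold higher number from compound 1 to compound 4 (0.01 log units; within the scatter) is therefore small. For compound 4 the estimated value is 6500 nM, with an expected range of 2500 nM to 17000 nM.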

Compound 4, half-maximal inhibitory concentration: 6640 nM
For compound 4 the middle estimate is 1.0-fold (0.01 log units) below the measured one, and the stated range covers the measured number.
By their numbers in this assay, from the lowest: compounds 1 and 4 (each within the scatter of the next); then compound 2. At a limit, above all of these: compound 3.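

In this assay, among these compounds, the step of a 1.0-fold higher number from compound 1 to compound 4 (0.02 log units; within the scatter) is the first single change that can be read, and it lies within the scatter. At this place, on a saturated chain carbon bound to an amide-type nitrogen, 3-fluorophenyl and 4-methylphenyl therefore read alike, which compound 2 and compound 3 could not show, as each differs from compound 1 in more than one place. Nothing measured here explains why the two groups read alike.

The compounds shown do not say whether this tolerance extends beyond these two groups, for example to a phenyl ring carrying an amine or a carboxylic acid. They also leave open what a longer chain between the amide nitrogen and the ring would do.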